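Working notes: from compound 3 to compound 4

The source may hold more compounds than are shown below. What is called first, only, known or untested is meant among the compounds shown, and "the series" means these compounds.

Compound 1 `Cc1ccccc1Nc1nc(NC2CC2)ncc1Cl`: > 100000 nM as a limit
Compound 2 `Cc1ccc(Nc2ncc(Cl)c(Nc3ccccc3C)n2)cc1`: > 100000 nM as a limit
Compound 3 `CCN1CCN(c2ccc(Nc3ncc(Cl)c(Nc4ccccc4C)n3)nc2)CC1`: > 100000 nM as a limit

All three entries come from an ADME assay on L02 cells (Homo sapiens) for inhibition, read by CCK-8 assay, with a stated time of 48 h (on this read-out higher numbers stand for weaker inhibition of growth and lower numbers for stronger inhibition of growth), and none of them is a number. Compound 3 stands at the limit of > 100000 nM in this assay, at which 3 of the 3 values shown sit, and so has no readable place in the series. The structure to be measured next is compound 4 `Cc1ccccc1Nc1nc(Nc2ccc(N3CCCCC3)cn2)ncc1Cl` and the change that leads to it is piperidin-1-yl in place of 4-ethylpiperazin-1-yl on an aromatic carbon with the rest of the structure kept.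

Within the data shown here, the only measured step between two compounds that differ in one place is a step that the two limits leave unreadable from compound 1 to compound 2 and it concerns a different place in the structure. Its size cannot be read, so it offers no size to carry over to this change. The expectation therefore rests on compound 3 alone, whose > 100000 nM is a limit. No step beyond the scatter can be argued for in this assay in either direction, and a further limit is the most likely report. The expected step is a number no higher from compound 3 to compound 4 (the limit leaves the size open) as an estimate with no direction claimed. For compound 4 the estimate is 100000 nM with an expected range of 40000 nM to 200000 nM in this reading.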

Compound 4, concentration for 50% growth inhibition: 42400 nM
Estimate against measurement, compound 4: 2.4-fold (0.37 log units) above, within the range that was stated.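

In this assay, replacing 4-ethylpiperazin-1-yl with piperidin-1-yl on the aromatic carbon gives an at least 2.3-fold lower number from compound 3 to compound 4 (0.37 log units; beyond the scatter), and a lower number here stands for stronger inhibition of growth, so this place in the structure can move the read-out. The change is a single swap that alters several counted features together: the entering piperidin-1-yl has 6 heavy atoms, 1 ring hetero atom and 1 hydrogen-bond acceptor, whereas the leaving 4-ethylpiperazin-1-yl has 8 heavy atoms, 2 ring hetero atoms and 2 hydrogen-bond acceptors. The earlier step cannot be read, and compound 1, compound 2 and compound 3 each give only a limit, so this is the first readable step in the series, measured against: the limit of > 100000 nM in this assay, at which 3 of the 4 values shown sit.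

The compounds shown do not separate the loss of the ethyl group from the loss of the second ring nitrogen, so it stays open which of the two goes with the step. An unsubstituted piperazin-1-yl, a morpholin-4-yl or a 4-methylpiperidin-1-yl at the same place would bear on that question, and an open-chain dimethylamino group would show whether the ring itself matters.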